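The source may report more compounds than this note shows. Statements on the series, on what has been measured and on what is new or still open speak of the compounds shown alone.

Working notes on the series. Two compounds have numbers in a physicochemical assay for lipophilicity, read by HPLC, measured as chromatographic lipophilicity, at pH 7.4; a lower number here means a more polar compound, a higher number a more lipophilic compound. Compound 1, `CCCCCCCC(=O)NCCCO[C@H]1[C@H](C)O[C@@H](O[C@H]2[C@H](C)[C@@H](O[C@@H]3O[C@H](C)C[C@H](N(C)C)[C@H]3O)[C@](C)(O)C[C@@H](C)CN(C)[C@H](C)[C@@H](O)[C@](C)(O)[C@@H](CC)OC(=O)[C@@H]2C)C[C@@]1(C)OC`, gives 4.1 in this assay. Compound 2, `CC[C@H]1OC(=O)[C@H](C)[C@@H](O[C@H]2C[C@@](C)(OC)[C@@H](O)[C@H](C)O2)[C@H](C)[C@@H](O[C@@H]2O[C@H](C)C[C@H](N(C)C)[C@H]2O)[C@](C)(OC)C[C@@H](C)C(=O)N[C@H](C)[C@@H](O)[C@]1(C)O`, gives 2.41 in this assay, the lower of the two numbers and separated from compound 1 by more than the usual scatter. Among the measured compounds shown here, no single-point pair between the measured compounds has been computed, so no measured step is available for comparison.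

Compound 3, `CC[C@H]1OC(=O)[C@H](C)[C@@H](O[C@H]2C[C@@](C)(OC)[C@@H](OC(=O)CN(CC)CC)[C@H](C)O2)[C@H](C)[C@@H](O[C@@H]2O[C@H](C)C[C@H](N(C)C)[C@H]2O)[C@](C)(OC)C[C@@H](C)C(=O)N[C@H](C)[C@@H](O)[C@]1(C)O`, has not yet been measured in this assay. It differs from compound 2 by ((diethylamino)methyl)carbonyl in place of hydrogen on an oxygen on a saturated carbon.

Nothing in the two measured compounds shows a change of this kind, so the expected step rests on the change itself. A modest increase is expected, a number 0.49 log units higher from compound 2 to compound 3 (beyond the scatter), rather than a move beyond the scatter in the other direction. Compound 3 is accordingly expected to read 2.9 in this assay, within a range of 2.3 to 3.6.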

Compound 3, distribution coefficient: 3.86
Beside the measured number, compound 3's estimate is 0.96 log units below it; measured number above the stated range.
By their numbers in this assay, from the lowest: compound 2; then compounds 3 and 1 (each within the scatter of the next).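

In this assay, the first step measured at this oxygen, ((diethylamino)methyl)carbonyl in place of hydrogen, reads a number 1.45 log units higher from compound 2 to compound 3 (beyond the scatter). The hydroxy on this saturated carbon is therefore a place where a change to (((diethylamino)methyl)carbonyl)oxy moves the read-out well past repeat-measurement variation, which compounds without a single-point pair could not show. Nothing measured here speaks to the reason for the size of this step.

On these data alone, whether the step follows the carbonyl end or the diethylamino end of the group stays open: acetyl, which carries no amine, and a longer chain ending in the same diethylamino group would separate the two. Also open, as far as these compounds go, is whether the same group on another hydroxy of the shared core gives a step of similar size.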